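From 4-methoxyphenyl to 2-ethoxyphenyl on the shared core

The source may hold more compounds than are shown below. What is called first, only, known or untested is meant among the compounds shown, and "the series" means these compounds.

In a functional assay on HeLa cells (Homo sapiens) for inhibition, read by sulforhodamine B assay (on this read-out lower numbers stand for stronger inhibition and higher numbers for weaker inhibition), compound 1 `O=C1C=C(NC2CCCCC2)C(=O)c2c1nc1n2[C@H]2OC[C@@H](O)[C@H]2OC1` gives a limit, not a number: > 16000 nM. Compound 3 `COc1ccc(NC2=CC(=O)c3nc4n(c3C2=O)[C@H]2OC[C@@H](O)[C@H]2OC4)cc1` gives 4780 nM and compound 2 `CCOc1ccc(NC2=CC(=O)c3nc4n(c3C2=O)[C@H]2OC[C@@H](O)[C@H]2OC4)cc1` gives 3110 nM, two values within the scatter of each other. Compound 4 `CCOc1ccccc1NC1=CC(=O)c2nc3n(c2C1=O)[C@H]1OC[C@@H](O)[C@H]1OC3` carries 2-ethoxyphenyl in place of 4-methoxyphenyl on an amine nitrogen. Replacing cyclohexyl gave an at least 5.1-fold lower number from compound 1 to compound 2 (0.71 log units; beyond the scatter) and an at least 3.3-fold lower number from compound 1 to compound 3 (0.52 log units; beyond the scatter), both beyond the scatter, and both aromatic groups are retained in compound 4. Changing the chain on the oxygen gave a 1.5-fold higher number from compound 2 to compound 3 (0.19 log units; within the scatter), within the scatter. Among the compounds with values here, no measured step moves the ether group around the ring, so this part of the change is untested. The estimated step, a 1.2-fold higher number from compound 3 to compound 4 (0.06 log units; within the scatter), is expected to stay within the scatter. For compound 4 the expected value is 5500 nM, with an estimated range of 2000 nM to 15000 nM.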

Compound 4, half-maximal inhibitory concentration: 6040 nM
For compound 4 the middle estimate is 1.1-fold (0.04 log units) below the measured one, and the stated range covers the measured number.
By their numbers in this assay, from the lowest: compounds 2, 3 and 4 (each within the scatter of the next). At a limit, above all of these: compound 1.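

Carrying the ether on 2-ethoxyphenyl rather than 4-ethoxyphenyl changes little in this assay: both a 1.9-fold higher number from compound 2 to compound 4 (0.29 log units; within the scatter) and a 1.3-fold higher number from compound 3 to compound 4 (0.10 log units; within the scatter) stay within the scatter, the first measured sign that the place of the ether on the ring is tolerated here. The advantage of an aromatic group over cyclohexyl also persists with 2-ethoxyphenyl, at an at least 2.6-fold lower number from compound 1 to compound 4 (0.42 log units; beyond the scatter) in the series. That step is only a bound, set by the limit of compound 1: the limit of > 16000 nM in this assay, at which 1 of the 4 values shown sits.

Going by these compounds, whether an amine or a carboxylic acid on the phenyl ring, or a longer chain on the oxygen, would shift the number stays open.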